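Isopropyl added to the core of compound 1

The source may hold more compounds than are shown below. What is called first, only, known or untested is meant among the compounds shown, and "the series" means these compounds.

Values measured in a functional assay on RS4-11 cells (Homo sapiens) for inhibition, read by CCK-8 assay, with a stated time of 48 h (on this read-out lower numbers stand for stronger inhibition and higher numbers for weaker inhibition), are as follows
- compound 1 `O=C(NCCNS(=O)(=O)c1sccc1-c1ccccc1Oc1ccc(O)c(O)c1)Nc1cc(Cl)cc(Cl)c1` gives 6200 nM
- compound 2 `O=[N+]([O-])c1cccc(NC(=S)NCCNS(=O)(=O)c2ccc(-c3ccccc3OCc3cccc(O)c3)s2)c1` gives 9800 nM
- compound 3 `COc1ccc(Oc2ccccc2-c2ccsc2S(=O)(=O)N2CCN(C(=O)Nc3ccc([N+](=O)[O-])cc3)CC2)cc1OC` gives > 50000 nM as a limit

Among the compounds with values here, compound 1 and compound 2 give the only two numbers in the set, and these lie within the scatter of each other, so neither can be ranked over the other. The entry for compound 3 is a limit of the assay and not a number.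

Compound 4 `CC(C)c1ccc(Oc2ccc(O)c(O)c2)c(-c2ccsc2S(=O)(=O)NCCNC(=O)Nc2cc(Cl)cc(Cl)c2)c1` differs from compound 1 in one place, with isopropyl in place of hydrogen on an aromatic carbon of a six-membered aromatic ring of carbon only, meta to a large group and para to a 3,4-dihydroxyphenoxy group.

Within the data shown here, no two measured compounds differ in one place, so the set gives no direct measure of such a change. In this assay no step beyond the scatter is expected, and no direction is favoured. Among the measured compounds shown here, this expectation starts from compound 1 at 6200 nM as the only reference for the change. The estimated change is a 1.2-fold lower number from compound 1 to compound 4 (0.09 log units; within the scatter) in size. In this assay compound 4 is estimated at 5000 nM with an expected range from 1500 nM to 18000 nM around that figure.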

Compound 4, half-maximal inhibitory concentration: 6400 nM
Compound 4: the middle estimate sits 1.3-fold (0.11 log units) below what was measured; low and high end bracket the measured number.
By their numbers in this assay, from the lowest: compounds 1, 4 and 2 (each within the scatter of the next). At a limit, above all of these: compound 3.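

In this assay, placing isopropyl in place of hydrogen on an aromatic carbon, para to a 3,4-dihydroxyphenoxy group and meta to a large group, gives a 1.0-fold higher number from compound 1 to compound 4 (0.01 log units; within the scatter), so the two compounds cannot be told apart. Within the data shown here, this is the only pair in the set that differs in one place, and it shows that this position of the core of compound 1 can carry an isopropyl group, with its 3 heavy atoms, without a readable step on this read-out. The step is read between two numbers and not against a limit of the assay: the limit of > 50000 nM in this assay, at which 1 of the 4 values shown sits.

As far as these compounds go, whether the position would read the same with a primary amine, a carboxylic acid or a longer chain in place of the isopropyl group remains open, as a single substituent at a single position marks out no trend. From the compounds shown here alone, it also remains open whether isopropyl would give a similar result on a different compound of the series, such as compound 2, or at another carbon of the same ring.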